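The source may report more compounds than this note shows. Statements on the series, on what has been measured and on what is new or still open speak of the compounds shown alone.

Among the compounds with values here, in a functional assay on MDA-MB-231 cells (Homo sapiens) for inhibition, read by MTT assay, with a stated time of 48 h (a higher number here means a weaker inhibitor of growth, a lower number a stronger inhibitor of growth), compound 1 `CCc1cccc(Nc2ncnc3ccc(NC(=S)NCc4ccccc4)cc23)c1` gives 10500 nM and compound 2 `Oc1ccc(NC(=S)Nc2ccc3ncnc(Nc4cccc(Br)c4)c3c2)cc1` gives 17300 nM, so compound 2 stands within the scatter of the only other measured compound. Compound 3 `S=C(Nc1ccc(Cl)c(Cl)c1)Nc1ccc2ncnc(Nc3cccc(Br)c3)c2c1` has 3,4-dichlorophenyl in place of 4-hydroxyphenyl on an amide-type nitrogen. Within the data shown here, no measured pair shows this change, so the expectation is tentative: a modest step toward a lower number, near the edge of the scatter. The expected step is a 2.0-fold lower number from compound 2 to compound 3 (0.31 log units; beyond the scatter). For compound 3 the estimated value is 8500 nM, with an expected range of 3000 nM to 24000 nM.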

Compound 3, concentration for 50% growth inhibition: 4800 nM
The estimate for compound 3 lay 1.8-fold (0.25 log units) above the measured number, and the stated range covers the measured number.
By their numbers in this assay, from the lowest: compound 3; then compounds 1 and 2 (each within the scatter of the next).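

With 3,4-dichlorophenyl in place of 4-hydroxyphenyl on the amide-type nitrogen, this assay records a 3.6-fold lower number from compound 2 to compound 3 (0.56 log units; beyond the scatter). Within the data shown here, this is the first step between measured compounds that differ in one place, and it shows that the aryl group on this nitrogen can move the number beyond the scatter, though only modestly. Nothing available explains the shift.

The compounds shown leave open whether a single chlorine would give the same step, and how an amine or a carboxylic acid on this ring would read. Going by these compounds, whether the step carries over to other groups on the shared core also remains open.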